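This account rests on a few compounds, and the source may have more. Where it says the series, first, only, none or still open, it means among the compounds named here.

Of the compounds shown here, three built on one shared core have been measured in an assay on isolated protein for inhibition of hexosaminidase D (Homo sapiens), tested at 10 uM; on this read-out lower numbers stand for less inhibition and higher numbers for more inhibition at the one concentration tested (going by the name of the read-out). Compound 1 `CC(=O)Nc1ncc(CN2CCN(CC(=O)NC3CCCCC3)CC2C)s1` gives 101% in this assay. Compound 3 `CC(=O)Nc1ncc(CN2CCN(CC(=O)Nc3ccc(Cc4ccccc4)cc3)CC2)s1` gives 101% in this assay. Compound 2 `CC(=O)Nc1ncc(CN2CCN(CC(=O)Nc3ccc(N4CCN(C(C)=O)CC4)cc3)CC2C)s1` gives 73.5% in this assay, which is the lowest of the three numbers; both other compounds stand higher by more than the usual scatter, so the inhibition of compound 2 in this assay is lower than that of the other two at this concentration.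

Compound 4 `CC(=O)Nc1ncc(CN2CCN(CC(=O)Nc3ccc(Cc4ccccc4)cc3)CC2C)s1` has not yet been measured. It is reached from compound 2 by one structural change: benzyl in place of 4-acetylpiperazin-1-yl on an aromatic carbon. Compound 3 carries the same benzyl group on an aromatic carbon and gives 101% in this assay, while compound 1, which shares the core, gives 101% in this assay. Going by the values given here, no measured pair shows this exact change, so the size of the step must be estimated rather than read off.

Compound 4 is expected to rise well beyond the scatter, with an estimated step of a number 23.5 percentage points higher from compound 2 to compound 4 (beyond the scatter) from compound 2. The estimate for compound 4 in this assay is 97%, with a likely range from 85% to 105%, because compound 3 gives 101%.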

Compound 4, a percentage reported as inhibition, at one concentration (the size of the read-out at that concentration, not a potency): 107%
Compound 4: middle estimate off by 10 percentage points, on the low side; the whole stated range lies below it.
By their numbers in this assay, from the lowest: compound 2; then compounds 1, 3 and 4 (each within the scatter of the next).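

In this assay, going by these compounds alone, benzyl in place of 4-acetylpiperazin-1-yl on an aromatic carbon, para to a large group, gives a large rise (a number 33.5 percentage points higher from compound 2 to compound 4 (beyond the scatter)), the first step at this position that can be read directly rather than inferred. Methyl in place of hydrogen on a saturated ring carbon gives a step within the scatter (a number 6 percentage points higher from compound 3 to compound 4 (within the scatter)), so with benzyl on the aromatic ring this methyl makes no visible difference in this assay, and the lower number of compound 2 goes with its 4-acetylpiperazin-1-yl group rather than with the methyl. Nothing available here explains why these two groups give such different numbers.

From the compounds shown here alone, it remains open whether the high number needs benzyl itself, or whether a smaller group on the same aromatic carbon, such as an amine or a carboxylic acid, would give a high number too. Since the read-out comes from a single concentration and is not a potency, it also leaves open whether compound 3 and compound 4 would differ in a full concentration series.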